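A bromine on the acetyl of a small lactone

A few compounds are considered here, and "the series" means these few. Any claim that something is new, unique, unknown or untested is made for them only; others in the source may bear on it.

Compound 1 `CC(=O)O[C@@H]1OC(=O)[C@](C)(C(C)=O)[C@@H]1C` is a small lactone carrying an acetyl group and a methyl group on one ring carbon. In a functional assay on B16 cells (Mus musculus) for cytotoxicity, read by MTT assay (on this read-out lower numbers stand for stronger inhibition and higher numbers for weaker inhibition), compound 1 gives 4000 nM. Among the results shown, this is the only true number; the other result is a limit of the assay. Compound 2 `CC(=O)O[C@@H]1OC(=O)[C@](OC(C)=O)(C(C)=O)[C@@H]1C` carries an acetoxy group where compound 1 has the methyl. In this assay compound 2 reaches only the assay limit, > 50000 nM. The step of an at least 12-fold higher number from compound 1 to compound 2 (1.09 log units; beyond the scatter) is a large loss, ending at the limit of > 50000 nM in this assay, at which 1 of the 2 values shown sits. Compound 3 `CC(=O)O[C@@H]1OC(=O)[C@](C)(C(=O)CBr)[C@@H]1C` is not yet measured; it keeps that methyl and alters the acetyl instead: bromo in place of hydrogen on a saturated chain carbon bound to a carbonyl carbon. Among the measured compounds shown here, no measured step touches this position, so the step from compound 1 to compound 2 gives no direct guide. Compound 3 is expected to give about 2000 nM in this assay, with a range of 500 nM to 8000 nM. The expected step of a 2.0-fold lower number from compound 1 to compound 3 (0.30 log units; within the scatter) is thus small.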

Compound 3, half-maximal inhibitory concentration: 6000 nM
Estimate against measurement, compound 3: 3.0-fold (0.48 log units) below, and the stated range covers the measured number.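

In this assay, bromo in place of hydrogen on a saturated chain carbon bound to a carbonyl carbon gives a 1.5-fold higher number from compound 1 to compound 3 (0.18 log units; within the scatter), so this change to the acetyl leaves the number within the usual scatter. Among the compounds shown here, this is the first measured change at this position, and it shows that the acetyl can carry a bromine with no clear gain or loss in this assay. Compound 3 also gives a true number, so its step can be read in full, and the large loss seen on replacing the methyl with acetoxy does not appear with this change: the limit of > 50000 nM in this assay, at which 1 of the 3 values shown sits.

As far as these compounds go, whether chlorine or iodine on the same carbon would behave like bromine remains open. So does whether an amine or a longer chain in that place would shift the number beyond the scatter.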